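Same Small Change, Measured Once, Expected Again

A few compounds are considered here, and "the series" means these few. Any claim that something is new, unique, unknown or untested is made for them only; others in the source may bear on it.

Measured compounds:
compound 1 `CCCC1=C(N2CC2)C(=O)C(C(COC(N)=O)OC)=C(N2CC2)C1=O`: 5.63
compound 2 `CCC1=C(N2CC2)C(=O)C(C(COC(N)=O)OC)=C(N2CC2)C1=O`: 6.16
compound 3 `CCC1=C(N2CC2)C(=O)C(CCOC(N)=O)=C(N2CC2)C1=O`: 6.25

All three values come from a functional assay on L1210 cells (Mus musculus), with a stated time of 12 days; on this read-out lower numbers stand for lower potency and higher numbers for higher potency (the scale is a negative logarithm). Two single-point changes connect them. The first, (methyl in place of hydrogen on a saturated chain carbon, two bonds along the chain from a double-bonded ring carbon), gave a number 0.53 log units lower from compound 2 to compound 1 (beyond the scatter). The second, (hydrogen in place of methoxy on a saturated chain carbon bound to a double-bonded ring carbon and a saturated chain carbon), gave a number 0.09 log units higher from compound 2 to compound 3 (within the scatter), so compound 2 and compound 3 cannot be told apart on this read-out, while compound 1 sits clearly below both.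

Compound 4 `CCCC1=C(N2CC2)C(=O)C(CCOC(N)=O)=C(N2CC2)C1=O` differs from compound 3 by methyl in place of hydrogen on a saturated chain carbon, two bonds along the chain from a double-bonded ring carbon. This is the same change as that from compound 2 to compound 1, made at a place described in identical words. Since that earlier step was measured as a number 0.53 log units lower from compound 2 to compound 1 (beyond the scatter), the step from compound 3 to compound 4 is expected to be of similar size, a number 0.50 log units lower from compound 3 to compound 4 (beyond the scatter). Compound 4 is therefore estimated at 5.75, expected to fall between 5.35 and 6.15.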

Compound 4, logarithm of the reciprocal of the active concentration, log(1/C): 5.68
Beside the measured number, compound 4's estimate is 0.07 log units above it, and the stated range covers the measured number.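

In this assay, methyl in place of hydrogen again lowered the number, a number 0.57 log units lower from compound 3 to compound 4 (beyond the scatter), and the step was of matching size on both cores: the same change on two cores in this assay, a number 0.53 log units lower (beyond the scatter) from compound 2 to compound 1 and a number 0.57 log units lower (beyond the scatter) from compound 3 to compound 4, 0.04 log units apart, within the scatter of two such steps. Hydrogen in place of methoxy again made no distinguishable difference, a number 0.05 log units higher from compound 1 to compound 4 (within the scatter), and here too the cores agree: the same change on two cores in this assay, a number 0.09 log units higher (within the scatter) from compound 2 to compound 3 and a number 0.05 log units higher (within the scatter) from compound 1 to compound 4, 0.04 log units apart, within the scatter of two such steps. Each change therefore carried over between these two cores, but this rests on a single pair of steps per change and does not show that either would carry over to other cores in the series.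

On these data alone, whether a longer chain such as butyl would extend the step from ethyl to propyl remains open. So does whether an amine in place of methoxy would also leave the number unresolved.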